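The source may report more compounds than this note shows. Statements on the series, on what has been measured and on what is new or still open speak of the compounds shown alone.

Measured compounds in an assay on CHO cells for displacement of a labelled ligand from adenosine receptor A3 (Homo sapiens), read by scintillation counting, with a stated time of 120 min; on this read-out lower numbers stand for stronger inhibition and higher numbers for weaker inhibition:
Compound 1 `Nc1nc(NCc2cccs2)nc2sc(-c3ccco3)nc12` gives 6.43 nM.
Compound 2 `Nc1nc(NCc2ccncc2)nc2sc(-c3ccco3)nc12` gives 827 nM.
Compound 3 `Nc1nc(NCc2ccsc2)nc2sc(-c3ccco3)nc12` gives 3.14 nM.

All three share one core and differ only in the aromatic ring attached to the saturated chain carbon bound to a nitrogen on the aromatic ring. Compound 1 has the second highest of the three numbers. The step of a 2.0-fold lower number from compound 1 to compound 3 (0.31 log units; beyond the scatter) is modest, whereas a 130-fold higher number from compound 1 to compound 2 (2.11 log units; beyond the scatter) is large, as is a 260-fold lower number from compound 2 to compound 3 (2.42 log units; beyond the scatter).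

Compound 4 `Nc1nc(NCc2cccs2)nc2sc(-c3cccs3)nc12` has not yet been measured. Its change sits elsewhere: thiophen-2-yl in place of furan-2-yl on an aromatic carbon, on an aromatic carbon of the core, next to the ring nitrogen and next to the ring sulfur. Among the compounds with values here, none of the measured steps alters this part of the molecule, so no step bears directly on it. What the measured steps do show is that swapping one five-membered ring with one hetero atom for another of the same kind gave only a 2.0-fold lower number from compound 1 to compound 3 (0.31 log units; beyond the scatter), while the large steps came from a six-membered ring with nitrogen. For compound 4 a step no larger than the scatter in this assay is therefore expected, with no clear direction, as a 1.1-fold lower number from compound 1 to compound 4 (0.03 log units; within the scatter). Compound 4 is estimated at 6 nM, within a range from 2 nM to 20 nM.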

Compound 4, inhibition constant: 38 nM
Beside the measured number, compound 4's estimate is 6.3-fold (0.80 log units) below it; the measured number lies above the stated range.
By their numbers in this assay, from the lowest: compound 3; then compound 1; then compound 4; then compound 2.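

In this assay, the aromatic carbon of the core, next to the ring nitrogen and next to the ring sulfur, proves sensitive to the group it carries: thiophen-2-yl in place of furan-2-yl gives a 5.9-fold higher number from compound 1 to compound 4 (0.77 log units; beyond the scatter). This happens although the two groups have the same count of heavy atoms, the same five-membered aromatic ring with 1 hetero atom, the same hydrogen-bond counts and no net charge, so a swap of oxygen for sulfur in this ring is enough to move the number beyond the scatter. Within the data shown here, the earlier compounds changed only the ring on the saturated chain carbon, so this is the first sign that the other end of the molecule matters as well, and nothing available here explains the shift.

Only this one swap at this carbon is shown, so it remains open how a phenyl ring, a methyl group or an amine would fare there. Going by these compounds, it is also open whether thiophen-2-yl would cost a similar amount when paired with the thiophen-3-yl or pyridin-4-yl group on the chain carbon.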